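From 4-(trifluoromethyl)phenyl to 2-fluorophenyl on one oxygen

The source may hold more compounds than are shown below. What is called first, only, known or untested is meant among the compounds shown, and "the series" means these compounds.

- compound 1 `CC(C)[C@H](NC(=O)COc1cccc2ccccc12)C(=O)N[C@@H](CC(=O)O)C(=O)COc1cccc2ccccc12` gives 19000 nM
- compound 2 `CC(C)[C@H](NC(=O)COc1cccc2ccccc12)C(=O)N[C@@H](CC(=O)O)C(=O)COc1ccc(-c2ccccc2)cc1` gives 38700 nM
- compound 3 `CC(C)[C@H](NC(=O)COc1cccc2ccccc12)C(=O)N[C@@H](CC(=O)O)C(=O)COc1ccc(C(F)(F)F)cc1` gives 12300 nM

In a functional assay with Homo sapiens as the target (a higher number here means a weaker inhibitor, a lower number a stronger inhibitor), compound 3 gives 12300 nM. That number cannot be told apart from its nearest neighbour, with a 1.5-fold lower number from compound 1 to compound 3 (0.19 log units; within the scatter), but it does stand apart from the furthest, with a 3.1-fold lower number from compound 2 to compound 3 (0.50 log units; beyond the scatter).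

Compound 4 `CC(C)[C@H](NC(=O)COc1cccc2ccccc12)C(=O)N[C@@H](CC(=O)O)C(=O)COc1ccccc1F` keeps the shared core and carries 2-fluorophenyl in place of 4-(trifluoromethyl)phenyl on an oxygen on a saturated carbon. The counted difference is 2-fluorophenyl in place of 4-(trifluoromethyl)phenyl on an oxygen on a saturated carbon.

All three measured steps are changes at this same place, so all of them bear on the new one. The group swap behind a 1.5-fold lower number from compound 1 to compound 3 (0.19 log units; within the scatter) stayed inside the scatter, while a 2.0-fold higher number from compound 1 to compound 2 (0.31 log units; beyond the scatter) and a 3.1-fold lower number from compound 2 to compound 3 (0.50 log units; beyond the scatter) were modest. Swaps here have so far moved the number only a little, even between groups of quite different size. From the compounds shown here alone, none of the three measured compounds carries 2-fluorophenyl, however, so the data offer no direct guide to it, and the direction remains open.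

No change beyond the scatter is therefore expected, and the expected step is a 1.2-fold higher number from compound 3 to compound 4 (0.09 log units; within the scatter). For compound 4 the estimated value is 15000 nM, with an expected range from 6500 nM to 35000 nM.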

Compound 4, half-maximal inhibitory concentration: 15700 nM
Compound 4: middle estimate off by 1.0-fold (0.02 log units), on the low side; measured number inside the range.
By their numbers in this assay, from the lowest: compounds 3, 4 and 1 (each within the scatter of the next); then compound 2.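

In this assay, 2-fluorophenyl on this oxygen cannot be told apart from 4-(trifluoromethyl)phenyl (a 1.3-fold higher number from compound 3 to compound 4 (0.11 log units; within the scatter)) or from naphthalen-1-yl (a 1.2-fold lower number from compound 1 to compound 4 (0.08 log units; within the scatter)), so three groups that differ in their substituents and in their ring count give numbers within the scatter of one another. Only 4-phenylphenyl stands apart, with the new comparison (a 2.5-fold lower number from compound 2 to compound 4 (0.39 log units; beyond the scatter)) placing compound 2 beyond the scatter from compound 4 as well, although that step is modest and compound 2 is the one exception to the otherwise flat picture at this position. No measurement shown here explains why these groups behave alike or why 4-phenylphenyl differs from them.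

From the compounds shown here alone, all four groups at this place are built on aromatic rings of carbon only and carry no hydrogen-bond donors or acceptors, so it remains open how a pyridine ring, or a phenyl ring bearing an amine or a carboxylic acid, would behave there. The shared core also stays the same throughout, so these compounds cannot show whether replacing its naphthalen-1-yl ether on the other end with a different group would move the number further.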